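Trimming the Benzyl Ester Down to a Primary Amide

A few compounds are considered here, and "the series" means these few. Any claim that something is new, unique, unknown or untested is made for them only; others in the source may bear on it.

Three compounds of a shared core have been measured in a functional assay on MT4 cells (Homo sapiens); on this read-out higher numbers stand for lower toxicity in this test and lower numbers for higher toxicity in this test:
compound 1 `COC(=O)C(=O)CNC1=CS(=O)(=O)O[C@@]12[C@@H](CO[Si](C)(C)C(C)(C)C)O[C@@H](n1cc(C)c(=O)n(C)c1=O)[C@@H]2O[Si](C)(C)C(C)(C)C` gives 10300 nM
compound 2 `Cc1cn([C@@H]2O[C@H](CO[Si](C)(C)C(C)(C)C)[C@@]3(OS(=O)(=O)C=C3NCCC(N)=O)[C@H]2O[Si](C)(C)C(C)(C)C)c(=O)n(C)c1=O` gives 20000 nM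
compound 3 `Cc1cn([C@@H]2O[C@H](CO[Si](C)(C)C(C)(C)C)[C@@]3(OS(=O)(=O)C=C3NCC(=O)OCc3ccccc3)[C@H]2O[Si](C)(C)C(C)(C)C)c(=O)n(C)c1=O` gives 250000 nM

Compound 3 holds the highest of the three numbers, separated from the others by a 13-fold higher number from compound 2 to compound 3 (1.10 log units; beyond the scatter) and by a 24-fold higher number from compound 1 to compound 3 (1.39 log units; beyond the scatter). Compound 4 `Cc1cn([C@@H]2O[C@H](CO[Si](C)(C)C(C)(C)C)[C@@]3(OS(=O)(=O)C=C3NCC(N)=O)[C@H]2O[Si](C)(C)C(C)(C)C)c(=O)n(C)c1=O` differs from compound 3 by amino in place of benzyloxy on a carbonyl carbon. The step that bears most on this change is a 13-fold higher number from compound 2 to compound 3 (1.10 log units; beyond the scatter), which runs in the opposite direction, while a 1.9-fold higher number from compound 1 to compound 2 (0.29 log units; within the scatter) shows two short side chains at about the same level in this assay. Compound 4 is therefore expected to fall back toward those two, by about a 10-fold lower number from compound 3 to compound 4 (1.00 log units; beyond the scatter). The estimate for compound 4 is 25000 nM, with a range from 8000 nM to 80000 nM.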

Compound 4, half-maximal cytotoxic concentration: 14900 nM
Beside the measured number, compound 4's estimate is 1.7-fold (0.22 log units) above it, within the range that was stated.
By their numbers in this assay, from the lowest: compounds 1, 4 and 2 (each within the scatter of the next); then compound 3.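

In this assay amino in place of benzyloxy on this carbonyl carbon gives a 17-fold lower number from compound 3 to compound 4 (1.22 log units; beyond the scatter) and leaves compound 3 alone at the top of the four. Compound 4 sits within the scatter of both other short side chains, with a 1.3-fold lower number from compound 2 to compound 4 (0.13 log units; within the scatter) and a 1.4-fold higher number from compound 1 to compound 4 (0.16 log units; within the scatter) as the two steps to it. Nothing available explains the size of this step. Still open, as far as these compounds go, is whether a methyl ester or a carboxylic acid on the same carbonyl carbon would stay with compound 3 or fall in with compound 4.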